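A Thiazole Takes the Place of Pyridine

The source may report more compounds than this note shows. Statements on the series, on what has been measured and on what is new or still open speak of the compounds shown alone.

Three compounds share one core and differ only in the ring attached to it. Compound 1, `c1ccc(-c2ccncc2)c(OCC2=NCCN2)c1`, carries a pyridin-4-yl group; in a functional assay for activation of Alpha-1D adrenergic receptor (Homo sapiens), read by calcium flux (on this read-out higher numbers stand for an effect only at larger amounts of compound and lower numbers for an effect already at smaller amounts), compound 1 gives no number but only a limit of the assay, < 100000 nM. Compound 2, `c1cnc(-c2ccccc2OCC2=NCCN2)nc1`, carries a pyrimidin-2-yl group and likewise gives only a limit in this assay, < 100000 nM. Compound 3, `c1ccc(-c2ccoc2)c(OCC2=NCCN2)c1`, carries a furan-3-yl group; in this assay compound 3 gives 5.01 nM. Because (the limit of < 100000 nM in this assay, at which 2 of the 3 values shown sit), the steps a step that the two limits leave unreadable from compound 1 to compound 2, a step that the limit leaves unreadable from compound 1 to compound 3 and a step that the limit leaves unreadable from compound 2 to compound 3 cannot be sized; what can be said is that compound 3 reaches a number where compound 1 and compound 2 give only a limit.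

Compound 4, `c1ccc(-c2nccs2)c(OCC2=NCCN2)c1`, is not yet measured. It differs from compound 1 as follows: 1,3-thiazol-2-yl in place of pyridin-4-yl on an aromatic carbon. Within the data shown here, the step from compound 1 to compound 3 also exchanges the six-membered ring for a five-membered one, yet its size is not readable, so the only guide is that compound 3 reaches a number. Compound 4 is therefore expected to reach a number in this assay, estimated at 500 nM, with a range from 10 nM to 30000 nM. This estimate means an expected step that the limit leaves unreadable from compound 1 to compound 4.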

Compound 4, half-maximal effective concentration: 31.6 nM
The estimate for compound 4 lay 16-fold (1.20 log units) above the measured number; measured number inside the range.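

Compound 4 is the second compound, after compound 3, to reach a number in this assay. Among the four compounds shown, both rings that give a number at this place, on an aromatic carbon ortho to a group of 7 heavy atoms, are five-membered, while both that give only a limit are six-membered. The new result also shows that the five-membered rings are not interchangeable: exchanging furan-3-yl for 1,3-thiazol-2-yl gives a 6.3-fold higher number from compound 3 to compound 4 (0.80 log units; beyond the scatter), so compound 4 needs more compound for the same effect, and the steps to compound 4 from compound 1 and from compound 2 cannot be read because each of those two compounds gives only a limit: the limit of < 100000 nM in this assay, at which 2 of the 4 values shown sit.

The compounds shown leave open whether ring size itself matters, since the two five-membered rings also differ in their hetero atoms and in how they are attached, and the six-membered rings shown all contain nitrogen. A thiophene or a plain phenyl ring at this place would help separate these differences, and an open-chain group such as an amine would show whether a ring is needed there at all.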